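One Number and an Untested Change on the Shared Core

A few compounds are considered here, and "the series" means these few. Any claim that something is new, unique, unknown or untested is made for them only; others in the source may bear on it.

Among the compounds with values here, only one compound in this small series has a number so far. In an ADME assay on blood (Rattus norvegicus) for metabolic stability, with a stated time of 2 h (on this read-out higher numbers stand for a more stable compound and lower numbers for a less stable compound), the entry for compound 1 (`CC/C(=N/OC)c1ccc2oc(CSc3nnc(CNc4ccccc4)n3CC)nc2c1`) reads "not determined" (no result reported) and the entry for compound 2 (`CCn1c(CNc2ccccc2)nnc1SCc1nc2cc(C)ccc2o1`) reads "not determined" (no result reported) with no figure to compare. Within the data shown here, compound 3 (`CCC(O)c1ccc2oc(CSc3nnc(CNc4ccccc4)n3CC)nc2c1`) gives 80% and is the only compound with a number in this assay so far. Compound 4 (`CC/C(=N/O)c1ccc2oc(CSc3nnc(CNc4ccccc4)n3CC)nc2c1`) has yet to be tested there and differs from compound 3 in one place (a group of 5 heavy atoms (3 carbon, 1 nitrogen, 1 oxygen; no ring) in place of a group of 4 heavy atoms (3 carbon, 1 oxygen; no ring), on an aromatic carbon) on an aromatic carbon of the shared core. Among the measured compounds shown here, no measured step exists to draw on, and the expectation rests on compound 3 alone at 80% in this assay and stays loose. No shift beyond the usual scatter is expected in either direction, and the estimated change is a number 2 percentage points lower from compound 3 to compound 4 (within the scatter) in this assay on this basis. For compound 4 the expected value is 78% within an estimated range of 58% to 95% once the measurement is made.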

Compound 4, percent of the compound remaining: 100%
Compound 4: the middle estimate sits 22 percentage points below what was measured; measured number above the stated range.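

Within the data shown here, with the first readable step on this aromatic carbon of the shared core, this assay gives a number 20 percentage points higher from compound 3 to compound 4 (beyond the scatter). The read-out at this position therefore depends on the group placed there: exchanging 1-hydroxypropyl for the group of 5 heavy atoms, with its added nitrogen and its double bond outside aromatic rings, moves the number beyond the usual scatter. No measurement shown here accounts for the size or direction of this step.

This single pair cannot separate the part played by the added nitrogen from that of the double bond, and it establishes no trend beyond compound 3 and compound 4. From the compounds shown here alone, how a ketone, an amine or a longer chain on the same aromatic carbon would read in this assay remains open.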